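A few compounds are considered here, and "the series" means these few. Any claim that something is new, unique, unknown or untested is made for them only; others in the source may bear on it.

Compound 1, `CC(=O)N1CCN(c2cccc(-c3cc(C#N)c4c(N)ncnn34)c2)C(=O)C1(C)C`, gives 0.3.
Compound 2, `COc1ccc(-c2cc(Cl)c3c(N)ncnn23)cc1N1CCN(C(C)=O)C(C)(C)C1=O`, gives 0.17.
Compound 3, `CC(=O)N1CCN(c2cc(-c3cc(Cl)c4c(N)ncnn34)ccc2S(C)(=O)=O)C(=O)C1(C)C`, gives "not determined" (no result reported).

Among the measured compounds shown here, in an ADME assay on a cell-free system (serum, Homo sapiens) for protein binding (on this read-out lower numbers stand for a smaller free fraction and higher numbers for a larger free fraction), compound 2 gives 0.17, one of only two numbers reported. In this assay compound 1 gives 0.3, and the two numbers lie within the usual scatter of each other, so they cannot be told apart. For compound 3 this assay reports "not determined" (no result reported), so no number is available for it.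

The unmeasured compound 4 `CC(=O)N1CCN(c2cc(-c3cc(Cl)c4c(N)ncnn34)ccc2C(C)O)C(=O)C1(C)C` arises from compound 2 by the change (1-hydroxyethyl in place of methoxy on an aromatic carbon). For the measured compounds named here, no step between two measured compounds covers a change of this kind, so the expectation rests on compound 2 alone, and on the fact that the two numbers available do not separate. The step of a 1.3-fold higher number from compound 2 to compound 4 (0.11 log units; within the scatter) is therefore expected to stay within the usual scatter, with no direction preferred beyond it. Compound 4 is estimated at 0.22 in this assay, with an expected range from 0.12 to 0.4.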

Compound 4, unbound fraction: 0.34
For compound 4 the middle estimate is 1.5-fold (0.19 log units) below the measured one; low and high end bracket the measured number.
By their numbers in this assay, from the lowest: compounds 2, 1 and 4 (each within the scatter of the next).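

In this assay, among the compounds shown here, placing 1-hydroxyethyl instead of methoxy on the aromatic carbon, ortho to a large group and para to a large group, gives a 2.0-fold higher number from compound 2 to compound 4 (0.30 log units; within the scatter) and so provides the first direct comparison at this position. The free fraction therefore cannot be told apart across this change, even though the entering group has 1 hydrogen-bond donor and the leaving group has 0 hydrogen-bond donors. Nothing measured here accounts for the result.

This single pair does not separate the hydroxyl group from the added carbon, so hydroxymethyl or ethyl at the same place would be needed to tell them apart. Going by these compounds, whether an amine, a carboxylic acid or a longer chain there would give a step beyond the scatter remains open.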